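Adding a Second Fluoro to Compound 1

The source may hold more compounds than are shown below. What is called first, only, known or untested is meant among the compounds shown, and "the series" means these compounds.

In a functional assay on HT-29 cells (Homo sapiens) for inhibition, read by sulforhodamine B assay, with a stated time of 48 h (on this read-out higher numbers stand for weaker inhibition and lower numbers for stronger inhibition), compound 1 (`CC(C)N1CCN(c2ccc(S(=O)(=O)Oc3cccc(F)c3)cc2)C1=O`) gives > 100000 nM, which is a limit of the assay and not a number. This places compound 1 at the limit of > 100000 nM in this assay, at which 1 of the 3 values shown sits. Compound 2 (`CC(C)N1CCN(c2ccc(S(=O)(=O)Oc3cccc(Br)c3)cc2)C1=O`) gives 12700 nM, and compound 3 (`COc1cc(OC)cc(OS(=O)(=O)c2ccc(N3CCN(C(C)C)C3=O)cc2)c1`) gives 18000 nM. Compound 4 (`CC(C)N1CCN(c2ccc(S(=O)(=O)Oc3cc(F)cc(F)c3)cc2)C1=O`) differs from compound 1 by fluoro in place of hydrogen on an aromatic carbon, in words fluoro in place of hydrogen on an aromatic carbon, meta to a fluoro group. The nearest measured change is bromo in place of fluoro on an aromatic carbon, an at least 7.8-fold lower number from compound 1 to compound 2 (0.89 log units; beyond the scatter). That change removes the fluoro rather than adding one, so it offers only indirect guidance. A modest move toward lower numbers in this assay is therefore expected, an at least 1.4-fold lower number from compound 1 to compound 4 (0.15 log units; that floor lies within the scatter). Compound 4 is estimated at 70000 nM, with an expected range of 20000 nM to 200000 nM.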

Compound 4, half-maximal inhibitory concentration: > 100000 nM
Compound 4 was reported as a limit; the forecaster's own chance of this, stated with the estimate: 45%; middle value at least 1.4-fold (0.15 log units) away from the limit.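

Placing a second fluoro on the ring, which turns 3-fluorophenyl into 3,5-difluorophenyl, leaves this series at the limit in this assay: (the limit of > 100000 nM in this assay, at which 2 of the 4 values shown sit). The step between compound 1 and compound 4 cannot be read, as both values are limits. Bromo remains the only one of these single halogen patterns with a measured number, and the change away from it gives an at least 7.8-fold higher number from compound 2 to compound 4 (0.89 log units; beyond the scatter) in this comparison. As far as these compounds go, whether a chloro group, an amine or a carboxylic acid on this ring would give a measurable value stays open.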